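Hydroxy in Place of Dimethylamino: an Unmeasured Step

This account rests on a few compounds, and the source may have more. Where it says the series, first, only, none or still open, it means among the compounds named here.

Compound 2 `COc1cccc2c1C/C(=C\c1ccc(N(C)C)cc1)C2=O` was tested in an assay on membranes from brain for displacement of a labelled ligand from adenosine receptor A1 (Rattus norvegicus), read by radioligand binding; a higher number here means a weaker inhibitor, a lower number a stronger inhibitor. In this assay compound 2 gives > 100000 nM, which is a limit of the assay rather than a number. Compound 1 `COc1cc(OC)c(OC)cc1/C=C1\Cc2c(OC)cccc2C1=O` also gives a limit in this assay, > 100000 nM. For the measured compounds named here, compound 3 `O=C1/C(=C/c2cccc(O)c2)CCc2c(O)cccc21` is the one compound with a measured number in this assay, namely 1620 nM. Compound 2 therefore stands at the weak end of what has been seen, as the limit of > 100000 nM in this assay, at which 2 of the 3 values shown sit, shows.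

Compound 4 `COc1cccc2c1C/C(=C\c1ccc(O)cc1)C2=O` has not yet been measured. It differs from compound 2 in a single place: hydroxy in place of dimethylamino on an aromatic carbon. Going by the values given here, no measured pair shows exactly this change, so its size can only be estimated. Compound 3 also carries hydroxy groups and gives a number where compound 2 gives only a limit, but the two differ in more than one place, so this is not a clean comparison.

Compound 4 is expected to give 30000 nM, within 5000 nM to 150000 nM. The step from compound 2 to compound 4 is expected to be an at least 3.3-fold lower number from compound 2 to compound 4 (0.52 log units; beyond the scatter), toward a stronger inhibitor, though the result may again be reported only as a limit.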

Compound 4, inhibition constant: > 100000 nM
Compound 4: a limit, no number; the forecaster's own chance of this, stated with the estimate: 45%; middle value at least 3.3-fold (0.52 log units) away from the limit.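

Compound 4 gives > 100000 nM in this assay, a limit of the assay rather than a number, and compound 2 also gives only a limit, so no step can be read between them. The compounds shown leave open whether hydroxy in place of dimethylamino changes the inhibition constant at all, and in which direction.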